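This account rests on a few compounds, and the source may have more. Where it says the series, first, only, none or still open, it means among the compounds named here.

Compound 1 `CC(Oc1ccccc1Br)C1=NCCN1`, compound 2 `C=C(C)c1ccccc1OC(C)C1=NCCN1` and compound 3 `CCOc1ccccc1OC(C)C1=NCCN1` share one core and differ only in the group carried on the aromatic ring. In an assay on CHO cells for displacement of a labelled ligand from Alpha-2C adrenergic receptor (Homo sapiens) (on this read-out higher numbers stand for weaker inhibition and lower numbers for stronger inhibition), compound 1 gives 282 nM, compound 2 gives 603 nM and compound 3 gives 759 nM. The step of a 1.3-fold higher number from compound 2 to compound 3 (0.10 log units; within the scatter) lies within the scatter, whereas a 2.7-fold higher number from compound 1 to compound 3 (0.43 log units; beyond the scatter) lies beyond it, as does a 2.1-fold higher number from compound 1 to compound 2 (0.33 log units; beyond the scatter). Compound 4 `CC(C)Oc1ccccc1OC(C)C1=NCCN1` differs from compound 3 by methyl in place of hydrogen on a saturated chain carbon bound to an oxygen on an aromatic ring and a saturated chain carbon. Going by the values given here, none of the measured steps changes this part of the molecule; all three exchange the group on the aromatic carbon, so no direct precedent exists. Compound 4 is therefore expected to land close to compound 3. The expected step is a 1.3-fold higher number from compound 3 to compound 4 (0.10 log units; within the scatter). For compound 4 the estimate is 950 nM, within 400 nM to 2300 nM.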

Compound 4, inhibition constant: 398 nM
Compound 4: the middle estimate sits 2.4-fold (0.38 log units) above what was measured; measured number below the stated range.
By their numbers in this assay, from the lowest: compounds 1, 4, 2 and 3 (each within the scatter of the next, the first and the last beyond it).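

Adding a methyl to the saturated chain carbon bound to the oxygen, which turns ethoxy into isopropoxy, gives a step that stays within the scatter (a 1.9-fold lower number from compound 3 to compound 4 (0.28 log units; within the scatter)). Isopropoxy also cannot be told apart from 1-methylethenyl (a 1.5-fold lower number from compound 2 to compound 4 (0.18 log units; within the scatter)) or from bromo (a 1.4-fold higher number from compound 1 to compound 4 (0.15 log units; within the scatter)), whereas ethoxy lies beyond the scatter from bromo. Nothing shown here explains these numbers.

The compounds shown leave open whether a longer chain such as butoxy would move the number beyond the scatter. The same holds for an amine or a carboxylic acid at the end of that chain.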